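Swap of pyridin-2-yl for thiophen-3-yl in the series

A few compounds are considered here, and "the series" means these few. Any claim that something is new, unique, unknown or untested is made for them only; others in the source may bear on it.

Compound 2 `Oc1cccc(-c2cc(-c3ccccn3)nc(-c3ccccc3Cl)c2)c1` stands lowest of the two numbers in an assay on isolated protein for inhibition of DNA topoisomerase 1 (Homo sapiens), with a stated time of 30 min, tested at 100 uM (a lower number here means a weaker effect, a higher number a stronger effect of the compound at the concentration tested), at 0%. Its nearest measured neighbour is compound 1 `Oc1cccc(-c2cc(-c3cccs3)nc(-c3ccccc3Cl)c2)c1`, which in this assay gives 2.7%; the step of a number 2.7 percentage points lower from compound 1 to compound 2 (within the scatter) lies within the scatter, so the two values cannot be told apart. Compound 3 `Oc1cccc(-c2cc(-c3ccsc3)nc(-c3ccccc3Cl)c2)c1` has not yet been measured. It differs from compound 2 in one place: thiophen-3-yl in place of pyridin-2-yl on an aromatic carbon. For the measured compounds named here, the only measured step bears on this change loosely, as it exchanged thiophen-2-yl for pyridin-2-yl at the same place and produced nothing beyond the scatter. Nothing in these numbers points to a step beyond the scatter in this assay for compound 3. The expected value for compound 3 in this assay is 2%, with a range from 0% to 12%. The expected step of a number 2 percentage points higher from compound 2 to compound 3 (within the scatter) is accordingly small and within the scatter.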

Compound 3, a percentage reported as inhibition, at one concentration (the size of the read-out at that concentration, not a potency): 0%
Beside the measured number, compound 3's estimate is 2 percentage points above it; the measured number falls inside the stated range.
By their numbers in this assay, from the lowest: compounds 2, 3 and 1 (each within the scatter of the next).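

At the place next to the ring nitrogen, a five-membered ring with sulfur and a six-membered ring with nitrogen cannot be told apart in this assay, with no change at the digits printed from compound 2 to compound 3 (within the scatter). Moving the thiophene attachment from thiophen-2-yl to thiophen-3-yl also gives no readable difference, with a number 2.7 percentage points lower from compound 1 to compound 3 (within the scatter), so neither the ring type nor the attachment point separates these compounds. No supporting evidence is available to explain these results.

Going by these compounds, since all three aromatic groups give closely similar readings, it remains open whether any group at this place can lift the read-out clear of the scatter. On these data alone, an aminomethyl group, a carboxylic acid or a longer alkyl chain there would test this, and the roles of the 2-chlorophenyl and 3-hydroxyphenyl groups also remain open.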